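Hydroxy changes on the aromatic ring, one step ahead

The compounds below may be only part of what the source reports. "The series", "measured", "known", "first", "only" and "open" are said of these compounds alone.

compound 1 `O=C1c2c(O)cc(O)cc2O[C@@H](c2cc(O)ccc2O)[C@@H]1O`: 25400 nM
compound 2 `O=C1c2c(O)cc(O)cc2O[C@@H](c2ccccc2O)[C@@H]1O`: > 100000 nM (a limit of the assay, not a number)

In a physicochemical assay, read by spectrophotometry, with a stated time of 30 min (on this read-out lower numbers stand for an effect already at smaller amounts and higher numbers for an effect only at larger amounts of compound), compound 1 gives 25400 nM. For compound 2 the read-out is a limit of the assay rather than a number; compound 2 sits at the limit of > 100000 nM in this assay, at which 1 of the 2 values shown sits. Among the measured compounds shown here, the single measured step, an at least 3.9-fold higher number from compound 1 to compound 2 (0.59 log units; beyond the scatter), went with hydrogen in place of hydroxy on an aromatic carbon, and its true size is unknown beyond the limit.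

Compound 3 `O=C1c2c(O)cc(O)cc2O[C@@H](c2cccc(O)c2O)[C@@H]1O` is not yet measured. It differs from compound 2 by hydroxy in place of hydrogen on an aromatic carbon. For the measured compounds named here, the change is the reverse kind of the one measured step, though at another aromatic carbon, ortho to a hydroxy group. Going by the values given here, that step, an at least 3.9-fold higher number from compound 1 to compound 2 (0.59 log units; beyond the scatter), is the only guide, and it ran upward when a hydroxy left; a step downward beyond the scatter is therefore expected when a hydroxy enters. Compound 3 should accordingly come in lower than compound 2, with an expected step of an at least 8.3-fold lower number from compound 2 to compound 3 (0.92 log units; beyond the scatter). Compound 3 is estimated at 12000 nM, within 2500 nM to 70000 nM, with a real chance that the assay again reports only a limit.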

Compound 3, half-maximal effective concentration: 13500 nM
Beside the measured number, compound 3's estimate is 1.1-fold (0.05 log units) below it; the measured number falls inside the stated range.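

In this assay, hydroxy in place of hydrogen on an aromatic carbon, ortho to a hydroxy group, goes with an at least 7.4-fold lower number from compound 2 to compound 3 (0.86 log units; beyond the scatter). Together with an at least 3.9-fold higher number from compound 1 to compound 2 (0.59 log units; beyond the scatter), this ties the number to a hydroxy at a second aromatic carbon of the same ring, so the earlier link is no longer confined to a single carbon. The size of the new step stays a bound and not a measured difference, because compound 2 stands at a limit of the assay and not at a number: the limit of > 100000 nM in this assay, at which 1 of the 3 values shown sits.

How a methoxy group, an amine or a fluorine on this same aromatic carbon would read in this assay remains open, so the compounds shown do not tell whether the lower number requires a hydroxy there or would follow other groups as well. Also open, from the compounds shown here alone, is the reading when hydroxy groups on this ring are present at both aromatic carbons together.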